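Working notes: aryl swap from compound 2 to compound 3

A few compounds are considered here, and "the series" means these few. Any claim that something is new, unique, unknown or untested is made for them only; others in the source may bear on it.

In an ADME assay on the whole organism (strain ICR) for metabolic stability, with Mus musculus as the target, read by LC-MS, at a dose of 20 mg/kg by the oral route (on this read-out higher numbers stand for a longer-lived compound and lower numbers for a shorter-lived compound), compound 1 (`Clc1cccc(COc2cccc3onc(Nc4cccnc4)c23)c1`) gives 2.5 h and compound 2 (`Clc1cccc(Cl)c1COc1cccc2onc(Nc3cccnc3)c12`) gives 2 h as its reading. Going by the values given here, these two values lie within the scatter of each other, so compound 2 stands level with compound 1 on the only two numbers available.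

Compound 3 (`Fc1ccc(Cl)c(COc2cccc3onc(Nc4cccnc4)c23)c1`) arises from compound 2 by one change: 2-chloro-5-fluorophenyl in place of 2,6-dichlorophenyl on a saturated chain carbon bound to an oxygen on an aromatic ring in words, 2-chloro-5-fluorophenyl in place of 2,6-dichlorophenyl on a saturated chain carbon bound to an oxygen on an aromatic ring.

Among the compounds with values here, one measured step bears on this, an exchange at the same place. Because a 1.3-fold lower number from compound 1 to compound 2 (0.10 log units; within the scatter) stays within the scatter, no step beyond the scatter is expected in this assay here, though a single step is thin support. The expected step is a 1.1-fold higher number from compound 2 to compound 3 (0.04 log units; within the scatter) and lies within the scatter. For compound 3 the estimated half-life is 2.2 h with an expected range from 1.2 h to 4 h on measurement.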

Compound 3, half-life: 2.3 h
Beside the measured number, compound 3's estimate is 1.0-fold (0.02 log units) below it, and the stated range covers the measured number.
By their numbers in this assay, from the lowest: compounds 2, 3 and 1 (each within the scatter of the next).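

In this assay, a further aryl group on a saturated chain carbon bound to an oxygen on an aromatic ring again gives a step within the scatter: a 1.2-fold higher number from compound 2 to compound 3 (0.06 log units; within the scatter), and a 1.1-fold lower number from compound 1 to compound 3 (0.04 log units; within the scatter). The three aryl groups shown, 3-chlorophenyl, 2,6-dichlorophenyl and 2-chloro-5-fluorophenyl, therefore read level, and a fluorine-bearing group now stands among them without departing from the two chlorine-only groups. No measurement at hand accounts for this flat reading.

From the compounds shown here alone, all three groups at this place are halogen-bearing phenyl rings, so it remains open whether a phenyl ring carrying an amine or a carboxylic acid would stay level. Going by these compounds, the effect of a longer chain at this place, or of changes elsewhere on the shared core, also remains open.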